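Swapping the Aryl Group on the Amine of a Shared Core

The source may hold more compounds than are shown below. What is called first, only, known or untested is meant among the compounds shown, and "the series" means these compounds.

Measured compounds:
compound 1 `COc1ccc(NC2=CC(=O)c3c(nc4n3[C@H]3OC[C@@H](O)[C@H]3OC4)C2=O)cc1`: > 8000 nM
compound 2 `O=C1C=C(Nc2cccc(Cl)c2)C(=O)c2c1nc1n2[C@H]2OC[C@@H](O)[C@H]2OC1`: 6040 nM
compound 3 `CCCN(CCC)C1=CC(=O)c2nc3n(c2C1=O)[C@H]1OC[C@@H](O)[C@H]1OC3`: > 16000 nM

All three share one core and differ only in the group on the amine nitrogen attached to a double-bonded ring carbon. In a functional assay on HeLa cells (Homo sapiens) for inhibition, read by sulforhodamine B assay (on this read-out lower numbers stand for stronger inhibition and higher numbers for weaker inhibition), compound 1 gives only a limit, > 8000 nM, so its true number is not known. Compound 2, with (3-chlorophenyl)amino at that position, gives 6040 nM in this assay. Compound 3 also gives only a limit, > 16000 nM. For the measured compounds named here, the one measured step, an at least 2.6-fold higher number from compound 2 to compound 3 (0.42 log units; beyond the scatter), shows that replacing the aryl amine with dipropylamino weakens inhibition, as the limit of > 16000 nM in this assay, at which 1 of the 3 values shown sits, indicates.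

Compound 4 `O=C1C(Nc2cccc(F)c2)=CC(=O)c2c1nc1n2[C@H]2OC[C@@H](O)[C@H]2OC1` carries the change (3-fluorophenyl in place of 4-methoxyphenyl on an amine nitrogen). Going by the values given here, no measured step covers this exact swap, but compound 2 shows that an aryl amine bearing a halogen at the 3-position can give a measurable number, whereas compound 1 sits at the limit of > 8000 nM in this assay, at which 1 of the 3 values shown sits. A modest gain is therefore expected, with an at least 1.1-fold lower number from compound 1 to compound 4 (0.05 log units; that floor lies within the scatter) as the estimated step. Compound 4 is expected to give about 7000 nM, within 2500 nM to 20000 nM.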

Compound 4, half-maximal inhibitory concentration: > 8000 nM
Compound 4 ended at the assay's limit; the forecaster's own chance of this, stated with the estimate: 40%; at least 1.1-fold (0.05 log units) between middle value and limit.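

Compound 1 and compound 4 both sit at the same limit of the assay, so no step between them can be read: the limit of > 8000 nM in this assay, at which 2 of the 4 values shown sit.

The compounds shown leave open the true numbers of both compounds in this assay, and so whether 3-fluorophenyl in place of 4-methoxyphenyl changes inhibition at all.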